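Extending the methylamino chain: notes toward compound 3

The compounds below may be only part of what the source reports. "The series", "measured", "known", "first", "only" and "open" are said of these compounds alone.

Measured so far, in an assay on cells for inhibition of cytochrome P450 11B2, mitochondrial (Homo sapiens), read by HPLC, with a stated time of 90 min; on this read-out higher numbers stand for weaker inhibition and lower numbers for stronger inhibition:
compound 1 `CC(C)c1ncncc1-c1nc2cc(F)c(F)cc2n1C1CC1` gives 5 nM
compound 2 `CNc1ncncc1-c1nc2cc(F)c(F)cc2n1C1CC1` gives < 2 nM

The value of compound 2 in this assay is a limit of the assay and not a number (the limit of < 2 nM in this assay, at which 1 of the 2 values shown sits). Among the compounds with values here, the one measured step, an at least 2.5-fold lower number from compound 1 to compound 2 (0.39 log units; beyond the scatter), runs toward lower numbers, so compound 2 stands at the strong end of the two values shown, with only a limit to mark where.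

Compound 3 `Fc1cc2nc(-c3cncnc3NCCC(F)(F)F)n(C3CC3)c2cc1F` differs from compound 2 by 2,2,2-trifluoroethyl in place of hydrogen on a saturated chain carbon bound to a nitrogen on an aromatic ring. No measured step touches this change: the only step shown, an at least 2.5-fold lower number from compound 1 to compound 2 (0.39 log units; beyond the scatter), replaced the group on the aromatic carbon itself, whereas here the amine nitrogen stays and its methyl is extended. That step therefore gives no direction for the present one. Compound 2 sits at a limit in this assay, so a further lowering could not be seen, and only a worsening would register as a number. The working expectation is that compound 3 stays close to compound 2, with an at least 1.5-fold higher number from compound 2 to compound 3 (0.17 log units; that floor lies within the scatter) estimated as at most a small move toward higher numbers. Compound 3 is expected at 3 nM in this assay, within 1 nM to 10 nM.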

Compound 3, half-maximal inhibitory concentration: 3 nM
Compound 3: middle estimate and measured number agree at the digits printed; the measured number falls inside the stated range.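

The amine nitrogen on the aromatic carbon takes a much longer chain than methyl and still gives a low number in this assay, with an at least 1.5-fold higher number from compound 2 to compound 3 (0.17 log units; that floor lies within the scatter). The value of compound 2 is a limit of the assay and not a number, so that step has only a floor: the limit of < 2 nM in this assay, at which 1 of the 3 values shown sits.
Set against the isopropyl group on the same aromatic carbon, the (3,3,3-trifluoropropyl)amino group shows a 1.7-fold lower number from compound 1 to compound 3 (0.22 log units; within the scatter), so the two groups cannot be told apart on this read-out, and the clear step seen for methylamino is not shown for the longer chain.

As far as these compounds go, it stays open what a plain propyl chain without fluorine, a longer chain or a cyclic amine such as morpholine would give on the same nitrogen, and so whether the fluorine atoms of the chain matter here at all. Also open, from the compounds shown here alone, is how far the true value of compound 2 lies under its limit, which leaves the real size of the change on extending methyl to 3,3,3-trifluoropropyl unfixed.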